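The compounds below may be only part of what the source reports. "The series", "measured", "known", "first", "only" and "open" are said of these compounds alone.

Compound 3 `COc1cc(Cl)cc(-c2nn(-c3cccc(NC(=O)Nc4ccc(Cl)c(C(F)(F)F)c4)c3)cc2-c2ccncc2)c1` gives 3.99% in a functional assay on M14 cells (Homo sapiens) for inhibition, read by sulforhodamine B assay, with a stated time of 48 h, tested at 10 uM (a higher number here means a weaker effect of the compound at the concentration tested, a lower number a stronger effect), the second highest of the three numbers: compound 1 `COc1cc(Cl)cc(-c2nn(-c3cccc(NC(=O)c4ccc(Cl)c(Cl)c4)c3)cc2-c2ccncc2)c1` gives 68.9% and compound 2 `O=C(Nc1cccc(-n2cc(-c3ccncc3)c(-c3cc(O)cc(Cl)c3)n2)c1)Nc1ccc(Cl)c(Cl)c1` gives -69.2%. Going by the values given here, the only measured step, a number 64.9 percentage points lower from compound 1 to compound 3 (beyond the scatter), changes the amide to a urea and the aryl group at once, so it does not isolate the change to compound 4 `COc1cc(Cl)cc(-c2nn(-c3cccc(NC(=O)Nc4ccc(Cl)c(Cl)c4)c3)cc2-c2ccncc2)c1`, namely (chloro in place of trifluoromethyl on an aromatic carbon). Compound 2 carries the same (3,4-dichlorophenyl)amino urea as compound 4 but a hydroxy in place of methoxy, and its value sits far below compound 3. For compound 4 a downward step a number 29 percentage points lower from compound 3 to compound 4 (beyond the scatter) is therefore expected, with wide uncertainty. Compound 4 is estimated at -25%, within -75% to 25%.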

Compound 4, a percentage reported as activity, at one concentration (the size of the read-out at that concentration, not a potency): 18.7%
Beside the measured number, compound 4's estimate is 43.7 percentage points below it, and the stated range covers the measured number.
By their numbers in this assay, from the lowest: compound 2; then compound 3; then compound 4; then compound 1.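

In this assay, chloro in place of trifluoromethyl on this aromatic carbon gives only a modest change, a number 14.7 percentage points higher from compound 3 to compound 4 (beyond the scatter), while the amide-to-urea change, now read with 3,4-dichlorophenyl kept, gives a number 50.2 percentage points lower from compound 1 to compound 4 (beyond the scatter). The methyl on the oxygen accounts for a larger step, a number 87.9 percentage points higher from compound 2 to compound 4 (beyond the scatter). Nothing measured here accounts for these steps. Open, from the compounds shown here alone, are the effect of an amine or a carboxylic acid on this aromatic carbon, and whether the hydroxy in place of methoxy step holds with 4-chloro-3-(trifluoromethyl)phenyl on the urea.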